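Swapping the Halogen Ring Partner on a Nucleoside Thioether

The source may report more compounds than this note shows. Statements on the series, on what has been measured and on what is new or still open speak of the compounds shown alone.

Measured so far:
compound 1 `OC[C@H]1O[C@@H](n2cnc3c(SCc4ccccc4Cl)ncnc32)[C@H](O)[C@@H]1O` — 117 nM
compound 2 `OC[C@H]1O[C@@H](n2cnc3c(SCc4ccccc4I)ncnc32)[C@H](O)[C@@H]1O` — 19.5 nM
compound 3 `O=[N+]([O-])c1ccccc1CSc1ncnc2c1ncn2[C@@H]1O[C@H](CO)[C@@H](O)[C@H]1O` — 115 nM

All three share one core and differ only in the group on the aromatic ring attached through the sulfur-bound carbon. In an assay on isolated protein for inhibition of Equilibrative nucleoside transporter 1 (Homo sapiens) (a higher number here means a weaker inhibitor, a lower number a stronger inhibitor), compound 1 gives the highest of the three numbers, although compound 3 sits at practically the same level: a 1.0-fold lower number from compound 1 to compound 3 (0.01 log units; within the scatter). Compound 2 stands apart: a 6.0-fold lower number from compound 1 to compound 2 (0.78 log units; beyond the scatter).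

Compound 4 `Cc1cc(C)c(CSc2ncnc3c2ncn3[C@@H]2O[C@H](CO)[C@@H](O)[C@H]2O)c(C)c1` is the next step from compound 1: 2,4,6-trimethylphenyl in place of 2-chlorophenyl on a saturated chain carbon bound to a sulfur. Among the compounds with values here, no measured pair swaps the whole ring substituent pattern in this way, so the two steps from compound 1 are the only guide. Replacing chloro with iodo gave a modest gain, while replacing it with nitro gave none, so the change to compound 4 could plausibly land anywhere from no shift to a gain of similar size. A slight improvement is expected for compound 4, a 2.1-fold lower number from compound 1 to compound 4 (0.33 log units; beyond the scatter), with a central estimate of 55 nM and a range from 15 nM to 200 nM.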

Compound 4, inhibition constant: 1910 nM
For compound 4 the middle estimate is 35-fold (1.54 log units) below the measured one; measured number above the stated range.
By their numbers in this assay, from the lowest: compound 2; then compounds 3 and 1 (each within the scatter of the next); then compound 4.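

Swapping one group on the ring for another moved the number only modestly or not at all, but the whole-ring change to 2,4,6-trimethylphenyl is far less tolerated, with a 16-fold higher number from compound 1 to compound 4 (1.21 log units; beyond the scatter) and a 17-fold higher number from compound 3 to compound 4 (1.22 log units; beyond the scatter) as well. The widest gap in the set is a 98-fold higher number from compound 2 to compound 4 (1.99 log units; beyond the scatter) and it shows that this position can span a broad range of values, not just the narrow one the first three compounds suggested. The ring in compound 4 differs from the others in more than one way, and no evidence bearing on this loss is available.

Still open, as far as these compounds go, is whether a single methyl group on the ring would raise the number as well. The compounds shown also leave open how a methoxy group, an amine or a bromo group would compare with the iodo group of compound 2.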